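The compounds below may be only part of what the source reports. "The series", "measured", "known", "first", "only" and "open" are said of these compounds alone.

Of the compounds shown here, three have been measured in a functional assay on trachea (Cavia porcellus); on this read-out higher numbers stand for weaker inhibition and lower numbers for stronger inhibition. Compound 1 `CO[C@@]12CCN(C)C[C@H]1[C@H](c1ccc3ccccc3c1)C(C#N)=C(N)O2` gives 24200 nM in this assay. Compound 2 `CCN1CC[C@@]2(OC)OC(N)=C(C#N)[C@@H](c3ccc4ccccc4c3)[C@@H]2C1` carries methyl in place of hydrogen on a saturated chain carbon bound to an amine nitrogen in a ring; in this assay compound 2 gives 28300 nM, and the step of a 1.2-fold higher number from compound 1 to compound 2 (0.07 log units; within the scatter) lies within the scatter. Compound 3 `CCN1CC[C@@]2(OC)OC(N)=C(C#N)[C@@H](c3ccc(Cl)cc3)[C@@H]2C1` gives 14900 nM in this assay; the difference between the core of compound 3 and the core of compound 1 is not broken down here, and the two values lie close to one another.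

Compound 4 `CCCN1CC[C@@]2(OC)OC(N)=C(C#N)[C@@H](c3ccc(Cl)cc3)[C@@H]2C1` has not yet been measured in this assay. It differs from compound 3 by methyl in place of hydrogen on a saturated chain carbon, two bonds along the chain from an amine nitrogen in a ring. This is the same kind of change as that from compound 1 to compound 2, though not the same: there the methyl entered on a saturated chain carbon bound to an amine nitrogen in a ring, here on a saturated chain carbon two bonds along the chain from an amine nitrogen in a ring. Because the earlier step of a 1.2-fold higher number from compound 1 to compound 2 (0.07 log units; within the scatter) stayed within the scatter, a similarly small step is expected for compound 4. The step expected for compound 4 is a 1.1-fold higher number from compound 3 to compound 4 (0.06 log units; within the scatter). Compound 4 is accordingly expected to give about 17000 nM, most likely between 8000 nM and 36000 nM.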

Compound 4, half-maximal inhibitory concentration: 30300 nM
Compound 4: middle estimate off by 1.8-fold (0.25 log units), on the low side; low and high end bracket the measured number.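

In this assay the change from ethyl to propyl gives a 2.0-fold higher number from compound 3 to compound 4 (0.31 log units; beyond the scatter), a modest step just beyond the usual scatter, while the change from methyl to ethyl on the other core stayed within it. Set side by side, the two steps cannot be told apart: the same change on two cores in this assay, a 1.2-fold higher number (0.07 log units; within the scatter) from compound 1 to compound 2 and a 2.0-fold higher number (0.31 log units; beyond the scatter) from compound 3 to compound 4, 1.7-fold (0.24 log units) apart, within the scatter of two such steps. They therefore give no sign that the core alters the outcome of adding a methyl to this chain, but they do not prove that the change carries over unchanged: each core offers a single pair, and the methyl enters at a different place on the chain in each.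

The compounds shown leave open how a longer chain such as butyl, or a chain ending in a carboxylic acid, would read in this assay. They also leave open whether propyl on the core of compound 1 would give a step of the size seen on the core of compound 3.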